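The source may report more compounds than this note shows. Statements on the series, on what has been measured and on what is new or still open speak of the compounds shown alone.

Compound 2, `CC[C@@H](Nc1c(C#N)c(-c2ccc(-c3ncccc3C)cc2)nc2cnccc12)C(N)=O`, is the starting point of this step. In a physicochemical assay for lipophilicity, read by HPLC, at pH 7.5 (on this read-out higher numbers stand for higher lipophilicity and lower numbers for lower lipophilicity), compound 2 gives 2. Of the three measured compounds it sits in the middle of the numbers: compound 1, `N#Cc1c(-c2ccc(Br)cc2)nc2cnccc2c1NCC(N)=O`, gives 1.9 in this assay, and compound 3, `CC(C)(CC(N)=O)c1c(C#N)c(-c2ccc(Br)cc2)nc2cnccc12`, gives 2.1, and both of these lie within the scatter of the number for compound 2, so the three measured compounds cannot be told apart on this read-out.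

Going by the values given here, the only measured step that changes one place is a number 0.20 log units higher from compound 1 to compound 3 (within the scatter), and it concerns the group on the shared core, not the aryl substituent. Compound 4, `CC[C@@H](Nc1c(C#N)c(-c2ccc(-c3cccc(Cl)c3)cc2)nc2cnccc12)C(N)=O`, differs from compound 2 at the aryl substituent: 3-chlorophenyl in place of 3-methylpyridin-2-yl on an aromatic carbon. Among the compounds with values here, no measured step touches this position, so the expectation for compound 4 rests on the counted change alone, in which the entering group carries no hydrogen-bond acceptor where the leaving group carried one. On that basis the value of compound 4 in this assay is expected to be 3, within 2.4 to 3.6, which means an expected step of a number 1.00 log units higher from compound 2 to compound 4 (beyond the scatter).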

Compound 4, distribution coefficient: 3.1
Estimate against measurement, compound 4: 0.10 log units below; the measured number falls inside the stated range.
By their numbers in this assay, from the lowest: compounds 1, 2 and 3 (each within the scatter of the next); then compound 4.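

Going by these compounds alone, the aryl substituent, on an aromatic carbon para to a large group, is the first place in these compounds where this assay moves beyond the scatter: 3-chlorophenyl in place of 3-methylpyridin-2-yl gives a number 1.10 log units higher from compound 2 to compound 4 (beyond the scatter), whereas the one earlier step, at the group on the shared core, was a number 0.20 log units higher from compound 1 to compound 3 (within the scatter). The size of the new step does not go with a difference in heavy-atom count, which is equal for the two groups, and each group is a single six-membered aromatic ring; the counted difference is that the leaving group has a hydrogen-bond acceptor and the entering group has none. No evidence is available on what lies behind this step.

The compounds shown leave open whether the step goes with the loss of the ring nitrogen, with the chlorine, or with the loss of the methyl, as all of these change together between compound 2 and compound 4. As far as these compounds go, how an unsubstituted phenyl, a 3-methylphenyl or a phenyl carrying an amine would read at this place in this assay also stays open.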